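The source may hold more compounds than are shown below. What is called first, only, known or untested is meant among the compounds shown, and "the series" means these compounds.

Measured compounds:
Compound 1 `CC(=O)Nc1ccc(S(=O)(=O)NNC(=O)c2cccnc2Nc2ccc(Cl)cc2)cc1`: in a functional assay on HCC 2998 cells (Homo sapiens) for antiproliferative activity (on this read-out lower numbers stand for stronger inhibition of growth and higher numbers for weaker inhibition of growth), compound 1 gives > 100000 nM, which is a limit of the assay and not a number.
Compound 2 `O=C(NNS(=O)(=O)c1ccc(F)cc1)c1cccnc1Nc1ccc(Cl)cc1Cl`: in this assay compound 2 gives > 100000 nM, again a limit.

Compound 1 therefore stands at the edge of what the assay can report, and compound 2 shows the same; both measurements fall at the limit of > 100000 nM in this assay, at which 2 of the 2 values shown sit. Within the data shown here, no pair of measured compounds differs in a single place, so no measured step size is available.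

Compound 3 `O=C(NNS(=O)(=O)c1ccc(Cl)cc1Cl)c1cccnc1Nc1ccc(Cl)cc1` is not yet measured. It differs from compound 1 by one change: 2,4-dichlorophenyl in place of 4-acetamidophenyl on a sulfonyl sulfur. Because compound 1 sits at the limit of > 100000 nM in this assay, at which 2 of the 2 values shown sit, the step of a number no higher from compound 1 to compound 3 (the limit leaves the size open) is expected to be none beyond the scatter, with the result most likely reported again only as a limit. Compound 3 is estimated to give 100000 nM in this assay, within a range from 30000 nM to 300000 nM.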

Compound 3, concentration for total growth inhibition: 28800 nM
Beside the measured number, compound 3's estimate is 3.5-fold (0.54 log units) above it; the whole stated range lies above it.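

Replacing 4-acetamidophenyl with 2,4-dichlorophenyl on the sulfonyl sulfur gives an at least 3.4-fold lower number from compound 1 to compound 3 (0.54 log units; beyond the scatter), so the group at this position can change the read-out of this assay. With 28800 nM, compound 3 is the first compound shown to give a number rather than a limit, which means stronger inhibition of growth than the assay could report for the earlier compounds. The value > 100000 nM for compound 1 is a limit of the assay and not a number, so the size of this step is only a minimum: the limit of > 100000 nM in this assay, at which 2 of the 3 values shown sit.

The compounds shown do not separate the effect of adding the two chlorines from that of removing the acetamide. Going by these compounds, it also remains open whether a single chlorine, a methoxy group or a carboxylic acid on this phenyl ring would move the number further or reverse the change.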